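Compound 2 to compound 4: chain change, cytotoxicity expectation

This account rests on a few compounds, and the source may have more. Where it says the series, first, only, none or still open, it means among the compounds named here.

Compounds in hand are compound 1 `O=C1OC(Cc2nc(-c3ccc(Oc4ccccc4)cc3)no2)c2ccccc21`, compound 2 `COc1ccc(C(O)C2OC(=O)c3c(OC)cc(OC)cc32)cc1` and compound 3 `CCCOc1ccc(C(O)C2OC(=O)c3c(OC)cc(OC)cc32)cc1`, with compound 4 `COCCOc1ccc(C(O)C2OC(=O)c3c(OC)cc(OC)cc32)cc1` still unmeasured. In an ADME assay on RAW264.7 cells (Mus musculus) for cytotoxicity, read by MTT assay, with a stated time of 24 h, in the presence of a further agent that is not named here (on this read-out higher numbers stand for weaker inhibition and lower numbers for stronger inhibition), compound 1 gives > 40000 nM, a limit of the assay. In this assay compound 2 gives > 40000 nM, also a limit and not a number. In this assay compound 3 gives > 40000 nM, again a limit. Among the measured compounds shown here, the series so far stands at the limit of > 40000 nM in this assay, at which 3 of the 3 values shown sit.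

Compound 4 differs from compound 2 by methoxymethyl in place of hydrogen on a saturated chain carbon bound to an oxygen on an aromatic ring. For the measured compounds named here, the one measured step bearing on this change is a step that the two limits leave unreadable from compound 2 to compound 3, with ethyl entering at the same place. No step beyond the scatter is expected, in either direction, and the estimated step is a step that the limit leaves unreadable from compound 2 to compound 4. The expected value for compound 4 is 45000 nM, with an estimated range of 20000 nM to 80000 nM.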

Compound 4, half-maximal inhibitory concentration: > 40000 nM
Compound 4: a limit, no number (the forecaster's own chance of this, stated with the estimate: 90%); the middle value is on the limit's open side.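

In this assay compound 4 gives > 40000 nM, a limit and not a number, so the steps from compound 2 and compound 3 to compound 4 cannot be read. Still open is where the actual cytotoxicity of any compound shown lies, as the series rests on one limit: the limit of > 40000 nM in this assay, at which 4 of the 4 values shown sit.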